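From 4-fluorophenyl to 2-chlorophenyl: expected cell tolerance

The source may report more compounds than this note shows. Statements on the series, on what has been measured and on what is new or still open speak of the compounds shown alone.

Compound 1 `COc1ncc(-c2ccccc2)cc1[C@@H](c1ccccc1)[C@@](O)(CCN(C)C)c1cccc2ccccc12` gives > 50 ug/mL in a toxicity assay on Vero cells (Chlorocebus sabaeus) for cytotoxicity (a higher number here means that more compound is tolerated, a lower number that less compound is tolerated), which is a limit of the assay rather than a number.
Compound 2 `COc1nc(-c2ccc(F)cc2)ccc1[C@@H](c1ccccc1)[C@@](O)(CCN(C)C)c1cccc2ccccc12` gives > 50 ug/mL in this assay, again a limit.
Compound 3 `COc1ncc(-c2ccccc2)cc1[C@@H](c1ccccc1)[C@@](O)(CCN(C)C)c1cc(F)cc(F)c1` gives > 50 ug/mL in this assay, again a limit.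

Compound 2 thus stands at the limit of > 50 ug/mL in this assay, at which 3 of the 3 values shown sit. Among the compounds with values here, the only single-change comparison among the measured compounds is a step that the two limits leave unreadable from compound 1 to compound 3, so no readable size is available from it. Compound 4 `COc1nc(-c2ccccc2Cl)ccc1[C@@H](c1ccccc1)[C@@](O)(CCN(C)C)c1cccc2ccccc12` differs from compound 2 by 2-chlorophenyl in place of 4-fluorophenyl on an aromatic carbon. Within the data shown here, no measured step covers this kind of change, so there is no basis for expecting a move beyond the scatter in either direction. Compound 4 is therefore expected to remain at the limit as well, an expected step that the limit leaves unreadable from compound 2 to compound 4. For compound 4 the estimate in this assay is 60 ug/mL, within a range from 30 ug/mL to 150 ug/mL.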

Compound 4, half-maximal cytotoxic concentration: > 50 ug/mL
Compound 4: only a limit was reported (the forecaster's own chance of this, stated with the estimate: 85%); the middle value is on the limit's open side.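

Within the data shown here, compound 4 gives > 50 ug/mL in this assay, a limit and not a number, so no step between compound 2 and compound 4 can be read. What stays open is the concentration at which any compound shown stops being tolerated: the limit of > 50 ug/mL in this assay, at which 4 of the 4 values shown sit.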